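The compounds below may be only part of what the source reports. "The series", "measured", "known", "first", "only" and "open" are said of these compounds alone.

Compound 1 `CC(O)(C(=O)Nc1ccc(S(=O)(=O)c2ccccc2)c(F)c1)C(F)(F)F` gives 1800 nM in a functional assay (Cavia porcellus) with sulfonylurea receptors; K-ATP channels (Homo sapiens) as the target; on this read-out lower numbers stand for stronger inhibition and higher numbers for weaker inhibition.
Compound 2 `CC(O)(C(=O)Nc1ccc(S(=O)(=O)c2cccc(F)c2)cc1)C(F)(F)F` gives 3400 nM in this assay.
Compound 3 `Cc1cccc(C(=O)c2ccc(NC(=O)C(C)(O)C(F)(F)F)cc2)c1` reaches only a limit of this assay, > 30000 nM, not a number.

Of the two numbers shown, compound 2 stands at the top, and compound 1 lies within the usual scatter of it. Compound 4 `CC(O)(C(=O)Nc1ccc(S(=O)(=O)c2nccs2)cc1)C(F)(F)F` keeps the shared core of compound 2 and changes one group: 1,3-thiazol-2-yl in place of 3-fluorophenyl on a sulfonyl sulfur. Among the measured compounds shown here, no measured pair in this set differs by a change of this kind, so there is nothing to read a direction from. The step from compound 2 to compound 4 is therefore expected to be small, a 1.1-fold lower number from compound 2 to compound 4 (0.05 log units; within the scatter), within the scatter in either direction. Compound 4 is estimated to give 3000 nM in this assay, with a range from 1000 nM to 10000 nM.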

Compound 4, half-maximal inhibitory concentration: 1400 nM
Compound 4: middle estimate off by 2.1-fold (0.33 log units), on the high side, and the stated range covers the measured number.
By their numbers in this assay, from the lowest: compounds 4, 1 and 2 (each within the scatter of the next, the first and the last beyond it). At a limit, above all of these: compound 3.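

Putting 1,3-thiazol-2-yl in place of 3-fluorophenyl on the sulfonyl sulfur gives a 2.4-fold lower number from compound 2 to compound 4 (0.39 log units; beyond the scatter) in this assay. This shows that the place tolerates a five-membered aromatic ring with 2 hetero atoms, and that inhibition gets modestly stronger rather than being lost. Nothing measured here explains why the number moves.

This is a single step, so it sets no trend for other rings. From the compounds shown here alone, how an amine or a simple methyl group on the sulfonyl sulfur would fare remains open.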